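This account rests on a few compounds, and the source may have more. Where it says the series, first, only, none or still open, it means among the compounds named here.

Compound 1, `COc1cc(/C=C/C(=O)/C=C/c2cc(OC)c(OC)c(OC)c2)ccc1OCc1cn(CCOc2cc(=O)oc3ccccc23)nn1`, gives 22% in a functional assay on PC-3 cells (Homo sapiens) for inhibition, read by sulforhodamine B assay, with a stated time of 48 h, tested at 50 uM; a lower number here means less inhibition of growth, a higher number more inhibition of growth at the concentration tested. Compound 2, `COc1cc(/C=C/C(=O)/C=C/c2ccco2)ccc1OCc1cn(CCOc2cc(=O)oc3ccccc23)nn1`, gives 14% in this assay. Compound 3, `COc1cc(/C=C/C(=O)/C=C/c2cc(OC)c(OC)c(OC)c2)ccc1OCc1cn(CCCCCOc2cc(=O)oc3ccccc23)nn1`, is reported as "not active" (no number reported) in this assay.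

The change from compound 1 to compound 2 is furan-2-yl in place of 3,4,5-trimethoxyphenyl on a double-bonded chain carbon bound to a double-bonded chain carbon. In this assay it made a number 8 percentage points lower from compound 1 to compound 2 (within the scatter), a step that stays within the scatter of repeated measurements. The difference between the core of compound 3 and the core of compound 1 is not broken down here. Compound 4, `COc1cc(/C=C/C(=O)/C=C/c2ccco2)ccc1OCc1cn(CCCCCOc2cc(=O)oc3ccccc23)nn1`, is not yet measured; it stands to compound 3 as compound 2 stands to compound 1, the change being (furan-2-yl in place of 3,4,5-trimethoxyphenyl on a double-bonded chain carbon bound to a double-bonded chain carbon). The place of the change is worded identically in both pairs, so it counts as the same change, and it occurs twice among these four compounds.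

Compound 3 gave no number, and compound 4 is expected to sit low because the earlier step of a number 8 percentage points lower from compound 1 to compound 2 (within the scatter) hardly moved the read-out. Compound 4 is expected to give 8% in this assay, with a range from 0% to 20%, and it may well be reported as not active again.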

Compound 4, percent growth inhibition at one concentration: "not active" (no number reported)
The entry for compound 4 holds no number, so the estimate cannot be set against anything.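

Compound 3 and compound 4 are both reported without a number in this assay, so no step can be read between them. No supporting data bear on this result. The compounds shown leave open whether furan-2-yl in place of 3,4,5-trimethoxyphenyl changes growth inhibition at all on the core of compound 3.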